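Swapping the sulfonamide amino for a pyrrolidine ring

The source may report more compounds than this note shows. Statements on the series, on what has been measured and on what is new or still open speak of the compounds shown alone.

Measured compounds:
Compound 1 `Clc1cccc(Cl)c1Nc1nc2c(Nc3ccccc3)ncnc2s1`: 170 nM
Compound 2 `NS(=O)(=O)c1ccc(Nc2ncnc3sc(Nc4c(Cl)cccc4Cl)nc23)cc1`: 590 nM

Both compounds were tested in a functional assay on HEK293 cells for antagonist activity at transient receptor potential cation channel subfamily V member 1 (Rattus norvegicus), read by calcium flux; on this read-out lower numbers stand for stronger inhibition and higher numbers for weaker inhibition. Going by the values given here, compound 2 gives the higher of the two numbers, and the only step measured so far runs from it: a 3.5-fold higher number from compound 1 to compound 2 (0.54 log units; beyond the scatter). That step shows what happens when a sulfamoyl group is introduced on the aromatic ring; it says nothing yet about what happens when that same group is altered.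

Compound 3 `O=S(=O)(c1ccc(Nc2ncnc3sc(Nc4c(Cl)cccc4Cl)nc23)cc1)N1CCCC1` is such an alteration. Relative to compound 2 the change is pyrrolidin-1-yl in place of amino on a sulfonyl sulfur. Among the compounds with values here, no measured step touches the nitrogen of the sulfonyl group. Within the data shown here, the expectation for compound 3 rests only on the size of the one step known, a 3.5-fold higher number from compound 1 to compound 2 (0.54 log units; beyond the scatter), which sets a rough scale of how much this part of the molecule can move the read-out. The change from compound 2 to compound 3 is therefore expected to be a 1.2-fold lower number from compound 2 to compound 3 (0.07 log units; within the scatter), that is, within the scatter rather than a clear shift in either direction. Compound 3 is estimated to give 500 nM, with a plausible range from 150 nM to 2000 nM.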

Compound 3, half-maximal inhibitory concentration: 0.5 nM
Beside the measured number, compound 3's estimate is 1000-fold (3.00 log units) above it; the whole stated range lies above it.
By their numbers in this assay, from the lowest: compound 3; then compound 1; then compound 2.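

In this assay, going by these compounds alone, this position proves far more sensitive than the one earlier step suggested: pyrrolidin-1-yl in place of amino on the sulfonyl sulfur gives a 1200-fold lower number from compound 2 to compound 3 (3.07 log units; beyond the scatter), a much larger move than a 3.5-fold higher number from compound 1 to compound 2 (0.54 log units; beyond the scatter). Adding a sulfonyl group to the aromatic carbon therefore does not by itself raise the number, since the (pyrrolidin-1-yl)sulfonyl group gives a 340-fold lower number from compound 1 to compound 3 (2.53 log units; beyond the scatter), the opposite direction from the sulfamoyl group, and among these compounds what sits on the sulfur sets the direction of the step. No measurement available here explains why this change has so large an effect.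

The change swaps the hydrogen-bearing amino group for a ring whose nitrogen carries no hydrogen, so the compounds shown cannot tell which of these two differences matters. A dimethylamino group on the sulfur would have no hydrogen on its nitrogen and no ring, while a piperidine or morpholine ring would show whether the size and make-up of the ring count as well.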